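Swapping One Halogenated Phenyl for Another on a Ring Amine

The source may report more compounds than this note shows. Statements on the series, on what has been measured and on what is new or still open speak of the compounds shown alone.

Compound 1 `CCC1(CCCCN2CCC(C)CC2)C(=O)Nc2ccccc21` has in a functional assay on the whole organism (strain Wistar) with Rattus norvegicus as the target, with a stated time of 5 min (a higher number here means that more compound is needed for the effect, a lower number that less compound is needed), the entry "not determined" (no result reported), so it offers no number. Compound 2 `O=C1Nc2ccc(F)cc2C1CCCCN1CCN(c2ccc(F)cc2)CC1` gives in this assay the value > 10 mg/kg, which is a limit of the measurement and not a number; it sits at the limit of > 10 mg/kg in this assay, at which 1 of the 2 values shown sits. Compound 3 `O=C1Nc2ccc(F)cc2C1CCCCN1CCN(c2cccc(Cl)c2)CC1` carries 3-chlorophenyl in place of 4-fluorophenyl on an amine nitrogen in a ring. For the measured compounds named here, with no measured step of this kind available, the change is expected to stay within the usual scatter, a step that the limit leaves unreadable from compound 2 to compound 3 in this assay. Compound 3 is therefore estimated at 15 mg/kg, with a range from 5 mg/kg to 50 mg/kg.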

Compound 3, minimum effective dose: > 20 mg/kg
Compound 3: a limit, no number; the forecaster's own chance of this, stated with the estimate: 60%; middle value at least 1.3-fold (0.12 log units) from the limit.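

For the compounds shown here, compound 2 and compound 3 each give only a limit, not a number, in this assay, so no step between them can be read. Going by these compounds, whether 3-chlorophenyl and 4-fluorophenyl differ in minimum effective dose stays open.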